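A few compounds are considered here, and "the series" means these few. Any claim that something is new, unique, unknown or untested is made for them only; others in the source may bear on it.

Measured compounds in an assay for inhibition of serine/threonine-protein kinase PLK2 (Homo sapiens), read by FRET and Z'-LYTE, with a stated time of 1 h; on this read-out lower numbers stand for stronger inhibition and higher numbers for weaker inhibition:
compound 1 `CC[C@@H]1C(=O)N(C)c2cnc(-n3ccc4cc(C(N)=O)ccc43)nc2N1C1CCCC1` gives 28.5 nM
compound 2 `CCC1C(=O)N(C)c2cnc(-n3ccc4cc(C(=O)NC(C)C)ccc43)nc2N1c1ccn(C)n1` gives 125 nM
compound 3 `CCCNS(=O)(=O)c1ccc(Nc2ncc3c(n2)N(c2ccn(C)n2)C(CC)C(=O)N3C)cc1` gives 190 nM

Compound 1 stands at the lowest number of the three. Compound 2 sits beyond the scatter above it, and compound 3 lies further still, so compound 1 is the strongest inhibitor among the measured set. The three structures differ in several places at once, so none of the gaps between them isolates a single change.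

Compound 4 `CC[C@@H]1C(=O)N(C)c2cnc(-n3ccc4ccccc43)nc2N1C1CCCC1` keeps the core of compound 1 and alters only one position: hydrogen in place of carbamoyl on an aromatic carbon. Among the measured compounds shown here, no pair of measured compounds reports this change on its own, so the size of its effect is open. The carbamoyl carries one hydrogen-bond donor and one acceptor, and its removal is expected to weaken inhibition by a modest margin, a step of a 3.2-fold higher number from compound 1 to compound 4 (0.50 log units; beyond the scatter) from compound 1 to compound 4. Compound 4 is therefore estimated at 90 nM, within a range from 30 nM to 300 nM.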

Compound 4, half-maximal inhibitory concentration: 355 nM
The estimate for compound 4 lay 3.9-fold (0.60 log units) below the measured number; measured number above the stated range.
By their numbers in this assay, from the lowest: compound 1; then compounds 2, 3 and 4 (each within the scatter of the next, the first and the last beyond it).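

In this assay, among the compounds shown here, hydrogen in place of carbamoyl on this aromatic carbon gives a 12-fold higher number from compound 1 to compound 4 (1.10 log units; beyond the scatter), a large step and the first single-change comparison. With the rest of compound 1 held fixed, the carbamoyl at this position therefore counts for much of the inhibition, and this position cannot be treated as one where the substituent is dispensable. Nothing available explains the size of this step.

From the compounds shown here alone, whether the effect belongs to the carbamoyl itself or could also be carried by another group on this carbon, such as a nitrile, a carboxylic acid or an aminomethyl, stays open. Also open, going by these compounds, is whether removing the carbamoyl costs as much when the rest of the molecule differs from compound 1.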